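A few compounds are considered here, and "the series" means these few. Any claim that something is new, unique, unknown or untested is made for them only; others in the source may bear on it.

Measured compounds:
compound 1 `CC(c1cc2cccnc2cc1F)n1cnc2ncc(-c3cnn(C)c3)nc21` — 31.3 nM
compound 2 `CCC(c1cc2cccnc2cc1F)n1cnc2ncc(-c3cnn(C)c3)nc21` — "not determined" (no result reported)

In a functional assay on NCI-H1993 cells (Homo sapiens) for inhibition, read by CCK-8 assay, with a stated time of 72 h (a higher number here means a weaker inhibitor, a lower number a stronger inhibitor), compound 1 gives 31.3 nM. Within the data shown here, this is the only number, so compound 1 is the sole reference point; compound 2 carries no result and adds nothing to the picture. The next entry, compound 3 `CC(c1c(F)cc2ncccc2c1F)n1cnc2ncc(-c3cnn(C)c3)nc21`, differs from compound 1 by fluoro in place of hydrogen on an aromatic carbon, the rest of the shared core being unchanged. Among the measured compounds shown here, no pair of measured compounds differs in one place, so there is no measured step to set a scale for this kind of change. A fluoro entering in place of hydrogen on the six-membered aromatic ring of carbon only is a small change, and the step in this assay is expected to stay within the scatter of repeated measurements, with no clear direction: a 1.0-fold lower number from compound 1 to compound 3 (0.02 log units; within the scatter). Compound 3 is accordingly estimated at 30 nM, with a likely range from 10 nM to 100 nM.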

Compound 3, half-maximal inhibitory concentration: 35.5 nM
For compound 3 the middle estimate is 1.2-fold (0.07 log units) below the measured one; the measured number falls inside the stated range.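

In this assay, among these compounds, fluoro in place of hydrogen on an aromatic carbon gives a 1.1-fold higher number from compound 1 to compound 3 (0.05 log units; within the scatter), the first step that can be read. This carbon, ortho to a fused ring and ortho to a large group, therefore accepts a fluoro in a compound that already carries another fluoro meta to it, and compound 1 and compound 3 cannot be told apart in this assay. No data bearing on the origin of this result are available.

A single fluoro gives no guide to how a larger group at this carbon, such as methoxy, an amine or a nitrile, would read in this assay. As far as these compounds go, the step to compound 2, with its longer chain, cannot be read, so the effect of that chain remains open.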